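Swapping the ester alkyl group: from compound 2 to compound 3

The source may report more compounds than this note shows. Statements on the series, on what has been measured and on what is new or still open speak of the compounds shown alone.

Of the compounds shown here, two have so far been measured in a functional assay (cardiac atrium) for agonist activity, with Cavia porcellus as the target; a higher number here means that more compound is needed for the effect, a lower number that less compound is needed. Compound 1 `CC1=NC(C)=C([N+](=O)[O-])C(c2ccncc2)/C1=C(\O)OCC(C)C` gives 8510 nM. Among the compounds with values here, compound 2 `CC1=NC(C)=C([N+](=O)[O-])C(c2cccnc2)/C1=C(\O)OC(C)(C)C` gives 14600 nM in this assay, the higher of the two numbers, but its only neighbour, compound 1, lies within the scatter of it, so no order can be read between them. Within the data shown here, the two differ in more than one place, and no single step is counted between them; their values show only that they sit close together.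

Compound 3 `CC1=NC(C)=C([N+](=O)[O-])C(c2cccnc2)/C1=C(\O)OCC(C)C` has not yet been measured. It differs from compound 2 in one place: isobutyl in place of tert-butyl on an oxygen on an unsaturated carbon. Compound 1 also carries an isobutyl on that oxygen, and because its value 8510 nM lies within the scatter of compound 2, the change alone is not expected to move the number beyond the scatter. For compound 3 in this assay the estimate is 10000 nM, with a range from 3500 nM to 30000 nM. The step of a 1.5-fold lower number from compound 2 to compound 3 (0.16 log units; within the scatter) is expected to stay within the usual scatter, leaning if anything toward a lower number.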

Compound 3, half-maximal effective concentration: 1740 nM
For compound 3 the middle estimate is 5.7-fold (0.76 log units) above the measured one, and the stated range ends above it.
By their numbers in this assay, from the lowest: compound 3; then compounds 1 and 2 (each within the scatter of the next).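

In this assay, the group on the oxygen proves to matter when the pyridin-3-yl is held fixed: isobutyl in place of tert-butyl gives an 8.4-fold lower number from compound 2 to compound 3 (0.92 log units; beyond the scatter) and places compound 3 clearly lowest of the three. With isobutyl held fixed, the place of the ring nitrogen matters as well, as pyridin-3-yl in place of pyridin-4-yl gives a 4.9-fold lower number from compound 1 to compound 3 (0.69 log units; beyond the scatter), so the closeness of compound 1 and compound 2 had concealed two separate steps, each beyond the scatter. Nothing given here accounts for either step.

Going by these compounds, it remains open whether the change from tert-butyl to isobutyl would give a similar step with pyridin-4-yl on the saturated ring carbon. On these data alone, how a longer chain or a benzyl group on that oxygen would read in this assay also remains open.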